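A few compounds are considered here, and "the series" means these few. Any claim that something is new, unique, unknown or untested is made for them only; others in the source may bear on it.

Working notes on the series. Compound 1 `CN1CCN(CCCCn2c3c(c4ccccc42)C(=O)c2c[n+]([O-])c4ccccc4c2C3=O)CC1` gives 100 nM in a functional assay on SH-SY5Y cells (Homo sapiens) for cytotoxicity, read by MTT assay, with a stated time of 72 h; a higher number here means a weaker inhibitor, a lower number a stronger inhibitor. Compound 2 `CC1(C)OC[C@H](Cn2cc(Cn3c4c(c5ccccc53)C(=O)c3c[n+]([O-])c5ccccc5c3C4=O)nn2)O1` gives 820 nM in this assay, and compound 3 `O=C1c2c[n+]([O-])c3ccccc3c2C(=O)c2c1c1ccccc1n2Cc1cn([C@H]2C[C@H](O)[C@@H](CO)O2)nn1` gives 620 nM in this assay; compound 1 thus holds the lowest number of the three, with the gaps to compound 3 and to compound 2 both beyond the scatter. Going by the values given here, the one recorded step, a 1.3-fold lower number from compound 2 to compound 3 (0.12 log units; within the scatter), concerns a different position and does not bear on the change to compound 4 `O=C1c2c[n+]([O-])c3ccccc3c2C(=O)c2c1c1ccccc1n2CCCN1CCC(O)CC1`, which is 4-hydroxypiperidin-1-yl in place of (4-methylpiperazin-1-yl)methyl on a saturated chain carbon, three bonds along the chain from an aromatic nitrogen. Among the compounds with values here, no measured pair shows this exchange, so no direction can be read from the data; the expectation is a step of small size, with wide uncertainty. Compound 4 is therefore expected to give 180 nM in this assay, within 60 nM to 550 nM. That estimate corresponds to an expected 1.8-fold higher number from compound 1 to compound 4 (0.26 log units; within the scatter).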

Compound 4, half-maximal inhibitory concentration: 130 nM
Estimate against measurement, compound 4: 1.4-fold (0.14 log units) above; low and high end bracket the measured number.
By their numbers in this assay, from the lowest: compounds 1 and 4 (each within the scatter of the next); then compounds 3 and 2 (each within the scatter of the next).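

Going by these compounds alone, the step of a 1.3-fold higher number from compound 1 to compound 4 (0.11 log units; within the scatter) in this assay is the first measured pair at this position, and it stays within the scatter. The exchange of 4-(4-methylpiperazin-1-yl)butyl for 3-(4-hydroxypiperidin-1-yl)propyl alters both the ring and the chain, yet the number stays near that of compound 1. No evidence bears on this result. With both parts changed at once, the contribution of each stays unresolved. From the compounds shown here alone, a 4-(4-hydroxypiperidin-1-yl)butyl chain, or a morpholine ring or carboxylic acid on the same chain, remains open.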